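Lactone side chain variation and maltase-glucoamylase inhibition

The source may hold more compounds than are shown below. What is called first, only, known or untested is meant among the compounds shown, and "the series" means these compounds.

Measured compounds:
compound 1 `C=C1CC[C@@H]2[C@](C)(CO)[C@H](O)CC[C@@]2(C)[C@@H]1/C=C/C1=C/C(=C/C)OC1=O`, 15.1%
compound 2 `C=C1CC[C@@H]2[C@](C)(CO)[C@H](O)CC[C@@]2(C)[C@@H]1/C=C/C1=C/C(=C/C=C(/C)CCC=C(C)C)OC1=O`, "not active" (no number reported)
compound 3 `C=C1CC[C@@H]2[C@](C)(CO)[C@H](O)CC[C@@]2(C)[C@@H]1/C=C/C1=C/C(=C/c2cccc(Br)c2)OC1=O`, 16.7%

In an assay on isolated protein for inhibition of Maltase-glucoamylase (Homo sapiens), tested at 100 uM (a higher number here means more inhibition at the concentration tested (going by the name of the read-out), a lower number less inhibition), compound 3 holds the highest of the two numbers, with compound 1 nearest and within the scatter; compound 2 carries no number. The next compound, compound 4 `C=C1CC[C@@H]2[C@](C)(CO)[C@H](O)CC[C@@]2(C)[C@@H]1/C=C/C1=C/C(=C/c2ccc(OC)cc2)OC1=O`, differs from compound 3 by 4-methoxyphenyl in place of 3-bromophenyl on a double-bonded chain carbon bound to a double-bonded ring carbon. Going by the values given here, the only measured step at this position is a number 1.6 percentage points higher from compound 1 to compound 3 (within the scatter), which lies within the scatter; no step between two aryl groups at this place has been measured. On that basis no step beyond the scatter is expected here, and the step of a number 0.7 percentage points lower from compound 3 to compound 4 (within the scatter) is an estimate at about no change. Compound 4 is therefore expected to give about 16%, within a range of 5% to 28%.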

Compound 4, a percentage reported as inhibition, at one concentration (the size of the read-out at that concentration, not a potency): 100%
Beside the measured number, compound 4's estimate is 84 percentage points below it; the measured number lies above the stated range.
By their numbers in this assay, from the lowest: compounds 1 and 3 (each within the scatter of the next); then compound 4.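

In this assay the group at this place can shift the read-out a long way: 4-methoxyphenyl in place of 3-bromophenyl gives a number 83.3 percentage points higher from compound 3 to compound 4 (beyond the scatter) and 4-methoxyphenyl in place of methyl gives a number 84.9 percentage points higher from compound 1 to compound 4 (beyond the scatter) on the same scale. An aryl group here is not enough on its own: compound 3, with 3-bromophenyl, stays within the scatter of compound 1. No measurement available explains the gap between the two aryl groups.

On these data alone, compound 3 and compound 4 differ both in the substituent and in where it sits on the phenyl ring, so the contribution of each remains open. Also open, as far as these compounds go, is whether an unsubstituted phenyl or a phenyl bearing an amine would reach the level of compound 4.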